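The source may report more compounds than this note shows. Statements on the series, on what has been measured and on what is new or still open speak of the compounds shown alone.

Compound 1, with the structure `CC(=O)OC[C@H]1[C@@]2(C)CC[C@H](Br)C(C)(C)[C@H]2CC[C@]1(C)O`, is examined in an ADME assay on MT2 cells (Homo sapiens) for cytotoxicity, read by XTT assay; on this read-out lower numbers stand for higher toxicity in this test and higher numbers for lower toxicity in this test. In this assay compound 1 gives only a limit, > 100000 nM. Compound 2, with the structure `CC(=O)OC[C@@H]1[C@@]2(C)CC[C@H](Br)C(C)(C)[C@@H]2CC[C@@]1(C)O`, shares every atom and bond with compound 1. In this assay, for the measured compounds named here, compound 2 yields the one plain number of the set, 40000 nM. Going by the values given here, the only other value shown, that of compound 1, is a limit. The step of an at least 2.5-fold lower number from compound 1 to compound 2 (0.39 log units; beyond the scatter) arises from a change of configuration alone, as the record the fact that compounds 1 and 2 differ only in the configuration as drawn shows, and its size is bounded only on one side because of the limit noted in the limit of > 100000 nM in this assay, at which 1 of the 2 values shown sits.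

Compound 3, with the structure `CC(=O)OC[C@H]1[C@@]2(C)CC[C@H](Br)C(C)(C)[C@@H]2CC[C@@]1(C)O`, now comes into view. Relative to compound 2 the change is the two compounds have the same atoms and bonds and differ only in configuration as drawn: 1 of 5 stereo elements differ; a stereocentre at a saturated ring carbon is drawn S in compound 2 and R in compound 3. Among the compounds with values here, the only measured step that bears on it is the one from compound 1 to compound 2, where a change at three stereocentres produced at least a modest shift; here a single stereocentre changes, so a smaller shift, of uncertain direction, is expected in this assay. The expected step is a 1.5-fold higher number from compound 2 to compound 3 (0.18 log units; within the scatter), and compound 3 is estimated at 60000 nM, between 25000 nM and 150000 nM.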

Compound 3, half-maximal cytotoxic concentration: 90000 nM
The estimate for compound 3 lay 1.5-fold (0.18 log units) below the measured number, and the stated range covers the measured number.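

In this assay, a change at a single stereocentre on a saturated ring carbon gives a 2.3-fold higher number from compound 2 to compound 3 (0.35 log units; beyond the scatter), with the atoms and bonds untouched, so this one centre is enough on its own to move the number beyond the scatter: the fact that compounds 2 and 3 differ only in the configuration as drawn. The earlier step changed three stereo elements at once and could not show what any one of them contributed, whereas this pair isolates one of those centres. The other new step, an at least 1.1-fold lower number from compound 1 to compound 3 (0.04 log units; that floor lies within the scatter), spans two stereocentres and rests on a limit, so its floor lies within the scatter and its true size stays unfixed: the limit of > 100000 nM in this assay, at which 1 of the 3 values shown sits.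

The compounds shown leave open how much each of the two stereocentres separating compound 1 and compound 3 contributes by itself, since the limit held by compound 1 hides any shift between them. They also leave open whether this sensitivity to configuration persists when the bromine gives way to a chlorine or an amine, or when the acetate ester gives way to a free hydroxyl or a longer chain.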